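Substituent change at the ring carbon: compound 3 to compound 4

The source may hold more compounds than are shown below. What is called first, only, known or untested is meant among the compounds shown, and "the series" means these compounds.

Measured so far:
compound 1 `O=C1NCCN(c2ccccn2)N1`: 26000 nM
compound 2 `O=C1NCCN(c2cccc(Cl)n2)N1`: 5600 nM
compound 3 `COc1cccc(N2CCNC(=O)N2)n1`: 9500 nM

In an assay on RBL-1 cells for inhibition of Polyunsaturated fatty acid 5-lipoxygenase (Rattus norvegicus) (a higher number here means a weaker inhibitor, a lower number a stronger inhibitor), compound 3 stands second highest of the three numbers. Its nearest neighbour is compound 2, and the gap a 1.7-fold higher number from compound 2 to compound 3 (0.23 log units; within the scatter) lies within the scatter. Compound 1 lies furthest, with a 2.7-fold lower number from compound 1 to compound 3 (0.44 log units; beyond the scatter) separating them.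

Compound 4 `O=C1NCCN(c2cccc(-c3cccs3)n2)N1` is not yet measured. It differs from compound 3 by thiophen-2-yl in place of methoxy on an aromatic carbon. The measured steps at that carbon are a 4.6-fold lower number from compound 1 to compound 2 (0.67 log units; beyond the scatter) and a 2.7-fold lower number from compound 1 to compound 3 (0.44 log units; beyond the scatter), both modest, together with a 1.7-fold higher number from compound 2 to compound 3 (0.23 log units; within the scatter), which stays within the scatter. For the measured compounds named here, no measured step exchanges a methoxy for a ring group at this carbon, so the two hydrogen-to-substituent steps are the only guide: each lowered the number, and the two substituents differed little from one another. For compound 4 a step within the scatter or a modest lowering is therefore expected, a 2.1-fold lower number from compound 3 to compound 4 (0.32 log units; beyond the scatter). The estimate for compound 4 in this assay is 4500 nM, with a range from 1300 nM to 16000 nM.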

Compound 4, half-maximal inhibitory concentration: 8200 nM
Compound 4: middle estimate off by 1.8-fold (0.26 log units), on the low side; the measured number falls inside the stated range.
By their numbers in this assay, from the lowest: compounds 2, 4 and 3 (each within the scatter of the next); then compound 1.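

In this assay, thiophen-2-yl at this aromatic carbon still gives a lower number than hydrogen (a 3.2-fold lower number from compound 1 to compound 4 (0.50 log units; beyond the scatter)), so the position tolerates a five-membered aromatic ring as well as chloro and methoxy. Set against the other two substituents (a 1.2-fold lower number from compound 3 to compound 4 (0.06 log units; within the scatter); a 1.5-fold higher number from compound 2 to compound 4 (0.17 log units; within the scatter)), the ring group stays within the scatter, so chloro, methoxy and thiophen-2-yl cannot be separated here despite the added ring. Nothing measured on these compounds accounts for this levelling.

The compounds shown leave open whether an amine, a carboxylic acid or a longer chain at this carbon would stay in the same range or move away from it. They also leave open whether the gain over hydrogen depends on this carbon, since every substituted compound carries its group in the same place.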